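Switching the phenoxy substituent on a pyrazole amide series

The source may report more compounds than this note shows. Statements on the series, on what has been measured and on what is new or still open speak of the compounds shown alone.

Compound 3 `CNC(=O)c1cccc(Cn2nc(C)c(NC(=O)c3ccc(COc4ccccc4C)cc3)c2C)c1` is the reference point. In a functional assay on MIA PaCa-2 cells (Homo sapiens) for antiproliferative activity, read by MTT assay, with a stated time of 72 h (on this read-out higher numbers stand for an effect only at larger amounts of compound and lower numbers for an effect already at smaller amounts), compound 3 gives 2100 nM, the lowest of the three numbers recorded. Compound 1 `Cc1nn(Cc2cccc(C(N)=O)c2)c(C)c1NC(=O)c1ccc(COc2ccccc2)cc1` gives 9200 nM in this assay, and compound 2 `CCNC(=O)c1cccc(Cn2nc(C)c(NC(=O)c3ccc(COc4ccccc4)cc3)c2C)c1` gives 11000 nM. Going by the values given here, the only single change measured, a 1.2-fold higher number from compound 1 to compound 2 (0.08 log units; within the scatter), sits at the amide-type nitrogen and falls within the scatter. Compound 3 differs from compound 1 both at that nitrogen and at the phenoxy ring; with the nitrogen change shown to matter little, its clearly lower number appears to travel with the 2-methylphenoxy group, although no measured step isolates that ring.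

Compound 4 `CNC(=O)c1cccc(Cn2nc(C)c(NC(=O)c3ccc(COc4ccc(OC)cc4)cc3)c2C)c1` is reached from compound 3 by 4-methoxyphenyl in place of 2-methylphenyl on an oxygen on a saturated carbon. Among the compounds with values here, no measured pair probes a change at this position, so the expectation rests only on what compound 3 shows against compounds 1 and 2. Losing the methyl that accompanied the lower number suggests the value of compound 4 is expected to move upward by about a 2.1-fold higher number from compound 3 to compound 4 (0.33 log units; beyond the scatter). Compound 4 is therefore estimated at 4500 nM, with a range from 1500 nM to 13000 nM in this assay.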

Compound 4, half-maximal effective concentration: 8000 nM
Beside the measured number, compound 4's estimate is 1.8-fold (0.25 log units) below it; low and high end bracket the measured number.
By their numbers in this assay, from the lowest: compound 3; then compounds 4, 1 and 2 (each within the scatter of the next).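

Going by these compounds alone, the step of a 3.8-fold higher number from compound 3 to compound 4 (0.58 log units; beyond the scatter) in this assay gives the first direct reading at the aryl group on an oxygen on a saturated carbon, and it shows that this position responds beyond the scatter, whereas the one step at the amide-type nitrogen, a 1.2-fold higher number from compound 1 to compound 2 (0.08 log units; within the scatter), stays within it. What had only been inferred for the 2-methylphenyl group now has a measured single change behind it, since replacing that group with 4-methoxyphenyl, with the rest of the molecule unchanged, gives the higher number. The data offer no measured explanation for this difference.

On these data alone, the step changes both the substituent and its place on the ring, so it remains open whether the lower number of compound 3 depends on the methyl group, on the 2-position, or on both. A 4-methylphenyl or a 2-methoxyphenyl group on the same oxygen would separate these two changes, while a 2-chlorophenyl group would show whether a group other than methyl at the 2-position goes with a similar number.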